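Swapping an Anilino for a Phenoxy Group

The source may hold more compounds than are shown below. What is called first, only, known or untested is meant among the compounds shown, and "the series" means these compounds.

The compounds here share one core, seen in compound 1 `CC(C)(C)Nc1nc(N)c(C(=O)N=C(N)N)nc1Cl`, compound 2 `NC(N)=NC(=O)c1nc(Cl)c(N2CCCC2)nc1N` and compound 3 `NC(N)=NC(=O)c1nc(Cl)c(Nc2ccccc2)nc1N`, and differ only in the group attached at one aromatic carbon. They were tested in an assay for inhibition of acid-sensing ion channel 3 (Homo sapiens), read by patch clamp, tested at 1 uM; a lower number here means less inhibition, a higher number more inhibition at the concentration tested (going by the name of the read-out). Compound 1 has no reported number, its entry being "not determined" (no result reported). Compound 2 gives 12%, and compound 3 gives 44%, which places compound 3 highest of the two numbers available. For the measured compounds named here, the single measured step, a number 32 percentage points higher from compound 2 to compound 3 (beyond the scatter), shows that exchanging the group at this carbon can move the inhibition a great deal.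

Compound 4 `NC(N)=NC(=O)c1nc(Cl)c(Oc2ccccc2)nc1N` differs from compound 3 by one change: phenoxy in place of anilino on an aromatic carbon. Going by the values given here, no measured step involves a phenoxy group, so there is no direct guide to the direction. Among the compounds with values here, the only comparison available, a number 32 percentage points higher from compound 2 to compound 3 (beyond the scatter), says that the inhibition depends strongly on what sits at this carbon, so a shift beyond the scatter seems more likely than none. With the anilino group tied to the highest number seen, the estimate leans toward a decrease. For compound 4 the expected inhibition is 30%, in a range from 8% to 55%. That estimate corresponds to an expected step of a number 14 percentage points lower from compound 3 to compound 4 (beyond the scatter).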

Compound 4, a percentage reported as inhibition, at one concentration (the size of the read-out at that concentration, not a potency): 23%
Compound 4: middle estimate off by 7 percentage points, on the high side; low and high end bracket the measured number.
By their numbers in this assay, from the lowest: compound 2; then compound 4; then compound 3.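

Phenoxy and anilino differ only in the atom joining the benzene ring to the shared core, oxygen in place of nitrogen, and the swap also removes the hydrogen-bond donor that anilino carries. In this assay, this single-atom exchange gives a number 21 percentage points lower from compound 3 to compound 4 (beyond the scatter), so the aromatic ring alone does not set the inhibition at this position, and the atom that links it matters as well. The phenoxy group still keeps some of the gain over the saturated ring, with a number 11 percentage points higher from compound 2 to compound 4 (beyond the scatter), which places it between pyrrolidin-1-yl and anilino, but no evidence is available on what lies behind this order.

From the compounds shown here alone, it remains open whether a sulfur link, as in a phenylthio group, or a longer link, as in a benzylamino group, would give a number nearer to that of compound 3 or compound 4. It is also unknown how a methoxy group or a fluorine on the benzene ring would change the inhibition, and compound 1, with its entry of "not determined" (no result reported), adds nothing to the comparison.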